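The compounds below may be only part of what the source reports. "The series", "measured", "known", "first", "only" and "open" are said of these compounds alone.

Measured compounds and their values in the rat liver microsome assay:

compound 1 `CCCCCOC(=O)N1CCN(C(=O)[C@H](CCC(=O)O)NC(=O)c2cc(N3CCC(COC)CC3)nc(-c3ccccc3)n2)CC1` — > 80%
compound 2 `CCCCCOC(=O)N1CCN(C(=O)[C@H](CCC(=O)O)NC(=O)c2nc(-c3ccccc3)cc(N3CCC(CN)CC3)n2)CC1` — > 80%
compound 3 `CCCCCOC(=O)N1CCN(C(=O)[C@H](CCC(=O)O)NC(=O)c2nc(-c3ccccc3)cc(N3CCC(COC)CC3)n2)CC1` — > 80%

In an ADME assay on microsomes from liver (Rattus norvegicus) for metabolic stability (a higher number here means that more of the compound is left, a lower number that less of the compound is left), compound 1 gives > 80%, which is a limit of the assay and not a number. Compound 2 gives > 80% in this assay, again a limit. Compound 3 gives > 80% in this assay, also a limit. All three values therefore sit at the limit of > 80% in this assay, at which 3 of the 3 values shown sit, and none of them tells where the compound actually stands beyond that limit.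

Going by the values given here, the only pair within the set that differs in one place is compound 2 and compound 3, and the step that the two limits leave unreadable from compound 2 to compound 3 is a step that the two limits leave unreadable: methoxy in place of amino on a saturated chain carbon bound to a saturated ring carbon cannot be sized from two limits.

Compound 4 `CCCCCOC(=O)N1CCN(C(=O)[C@H](CCC(=O)O)NC(=O)c2cc(N3CCC(CNC)CC3)nc(-c3ccccc3)n2)CC1` is not yet measured. It differs from compound 1 by methylamino in place of methoxy on a saturated chain carbon bound to a saturated ring carbon. Among the compounds with values here, no measured step bears on this change in a readable way, since the only comparable change, from compound 2 to compound 3, gave two limits. With compound 1, compound 2 and compound 3 all at the limit, no step beyond the scatter is expected in this assay, and the estimated step is a step that the limit leaves unreadable from compound 1 to compound 4. Compound 4 is expected to give about 85%, in a range from 65% to 95%, most likely reported again only as a limit.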

Compound 4, percent of the compound remaining: > 80%
Compound 4: a limit, no number; the forecaster's own chance of this, stated with the estimate: 65%; the middle value is on the limit's open side.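

In this assay compound 4 gives > 80%, a limit and not a number. No step can be read from compound 1 to compound 4 for methylamino in place of methoxy, as both values are limits: the limit of > 80% in this assay, at which 4 of the 4 values shown sit.

The compounds shown leave open where any of the four stands beyond that limit, and whether these changes have any effect in this assay.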